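The source may report more compounds than this note shows. Statements on the series, on what has been measured and on what is new or still open speak of the compounds shown alone.

Measured so far in a functional assay on HCT-116 cells (Homo sapiens) for inhibition, read by CCK-8 assay, with a stated time of 48 h; on this read-out higher numbers stand for weaker inhibition and lower numbers for stronger inhibition:
- Compound 1 `COc1cc(-c2cc3nccc(-c4cc(OC)c(OC)c(OC)c4)n3n2)cc(OC)c1OC`: > 10000 nM, a limit of the assay
- Compound 2 `COc1cc(-c2ccnc3cc(-c4ccc(F)cc4)nn23)cc(OC)c1OC`: 5030 nM
- Compound 3 `COc1cc(-c2cc3nccc(-c4c[nH]c5ccccc45)n3n2)cc(OC)c1OC`: > 10000 nM, a limit of the assay

Compound 2 is the only one of the three to give an actual number, so it has no measured neighbour to be ranked against. The other two readings are limits, and the set sits mostly at that ceiling: the limit of > 10000 nM in this assay, at which 2 of the 3 values shown sit.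

Compound 4 `COc1cc(-c2ccnc3cc(-c4ccc(Cl)cc4)nn23)cc(OC)c1OC` departs from compound 2 in one place: chloro in place of fluoro on an aromatic carbon. This puts chloro in place of fluoro on an aromatic carbon, para to a large group. Among the measured compounds shown here, no pair of measured compounds differs by a single change, so the data give no direct gauge of such a step. In this assay, only a small shift towards stronger inhibition is expected, one that may not clear the usual scatter. The expected change is a 1.4-fold lower number from compound 2 to compound 4 (0.16 log units; within the scatter). Compound 4 is estimated at 3500 nM, with an expected range of 1200 nM to 10000 nM.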

Compound 4, half-maximal inhibitory concentration: 3340 nM
Compound 4: middle estimate off by 1.0-fold (0.02 log units), on the high side, within the range that was stated.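

Among the compounds shown here, the swap from 4-fluorophenyl to 4-chlorophenyl is the first single change that can be read in this set, and in this assay it gives a 1.5-fold lower number from compound 2 to compound 4 (0.18 log units; within the scatter) and so does not separate the two halogens at this place, on an aromatic carbon para to a large group. The change exchanges one heavy atom for one heavy atom, and both compounds still give a number. For the compounds shown here, this pair therefore supplies the only readable step, while the rest of the set stands at a ceiling: the limit of > 10000 nM in this assay, at which 2 of the 4 values shown sit.

Going by these compounds alone, no step to compound 1 or compound 3 can be read. From the compounds shown here alone, it remains open whether a group of another kind in the same place, such as an amine, a nitrile or a carboxylic acid, would shift the number beyond the scatter.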